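From Fluorine to Two Hydroxyls: Estimating Compound 4

The source may hold more compounds than are shown below. What is called first, only, known or untested is meant among the compounds shown, and "the series" means these compounds.

Of the compounds shown here, three sharing one core have been tested in a functional assay on BGC-823 cells (Homo sapiens) for cytotoxicity, read by MTT assay, with a stated time of 48 h; on this read-out lower numbers stand for stronger inhibition and higher numbers for weaker inhibition. Compound 1, `O=C(CSc1nnc(-c2ccncc2)o1)N/N=C/c1ccc(F)cc1`, gives 17800 nM in this assay, the second highest of the three numbers. Compound 2, `O=C(CSc1nnc(-c2ccncc2)o1)N/N=C/c1ccccc1F`, gives 24000 nM, and compound 3, `O=C(CSc1nnc(-c2ccncc2)o1)N/N=C/c1cc(Br)ccc1O`, gives 9590 nM. The step of a 1.3-fold higher number from compound 1 to compound 2 (0.13 log units; within the scatter) and the step of a 1.9-fold lower number from compound 1 to compound 3 (0.27 log units; within the scatter) both stay within the scatter, while the step of a 2.5-fold lower number from compound 2 to compound 3 (0.40 log units; beyond the scatter) is modest but beyond it.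

Compound 4, `O=C(CSc1nnc(-c2ccncc2)o1)N/N=C/c1ccc(O)c(O)c1`, has not yet been measured. It differs from compound 1 in one place: 3,4-dihydroxyphenyl in place of 4-fluorophenyl on a carbon with a double bond to nitrogen. The step that bears most on this change is a 1.9-fold lower number from compound 1 to compound 3 (0.27 log units; within the scatter), where 5-bromo-2-hydroxyphenyl replaced 4-fluorophenyl and the number stayed within the scatter. Compound 4 carries 3,4-dihydroxyphenyl instead, so a small change, at most modest and toward a lower number, is expected in this assay. The number for compound 4 is therefore estimated at 10000 nM, with a likely range from 4000 nM to 28000 nM, meaning an expected step of a 1.8-fold lower number from compound 1 to compound 4 (0.25 log units; within the scatter).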

Compound 4, half-maximal inhibitory concentration: 1260 nM
Compound 4: middle estimate off by 7.9-fold (0.90 log units), on the high side; the whole stated range lies above it.
By their numbers in this assay, from the lowest: compound 4; then compounds 3, 1 and 2 (each within the scatter of the next, the first and the last beyond it).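

Until now, changing the group on the carbon with a double bond to nitrogen had moved the number by a modest step at most, but this position can clearly produce a much bigger shift. Putting 3,4-dihydroxyphenyl in place of 4-fluorophenyl brings a 14-fold lower number from compound 1 to compound 4 (1.15 log units; beyond the scatter), and putting it in place of 2-fluorophenyl brings a 19-fold lower number from compound 2 to compound 4 (1.28 log units; beyond the scatter). A hydroxyl group on the ring is not enough by itself to reach this level in this assay, since compound 3 also carries one and the replacement of its 5-bromo-2-hydroxyphenyl still brings a 7.6-fold lower number from compound 3 to compound 4 (0.88 log units; beyond the scatter).

Nothing available explains why 3,4-dihydroxyphenyl stands out. Going by these compounds, it also remains open whether this group needs all of its hydroxyl groups, and whether methoxy groups or an amine in their place would keep a number this low.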